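Trading isopropyl for trifluoromethyl in a cell toxicity test

A few compounds are considered here, and "the series" means these few. Any claim that something is new, unique, unknown or untested is made for them only; others in the source may bear on it.

Three related compounds have so far been tested in an ADME assay on H1-HeLa cells (Homo sapiens) for cytotoxicity, read by MTT assay, with a stated time of 3 days; on this read-out lower numbers stand for higher toxicity in this test and higher numbers for lower toxicity in this test. Compound 1 `CNC(=O)c1cc(Oc2ccc3c(C)c(-c4noc(C)n4)sc3c2)ccn1` gives > 100000 nM, which is a limit of the assay and not a number. Compound 2 `CCc1nc(-c2ccc(Oc3ccnc(C(=O)NC)c3)cc2)no1` gives 43700 nM, and compound 3 `CNC(=O)c1cc(Oc2ccc(-c3noc(C(C)C)n3)cc2)ccn1` gives 16100 nM, the lower of the two actual numbers.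

The next molecule, compound 4 `CNC(=O)c1cc(Oc2ccc(-c3noc(C(F)(F)F)n3)cc2)ccn1`, keeps the core of compound 3 and alters a single group: trifluoromethyl in place of isopropyl on an aromatic carbon of a five-membered aromatic ring with 2 nitrogen and 1 oxygen (trifluoromethyl in place of isopropyl on an aromatic carbon). Going by the values given here, only one measured step touches this same group. It is a 2.7-fold lower number from compound 2 to compound 3 (0.43 log units; beyond the scatter), a modest move beyond the scatter, made by putting methyl in place of hydrogen on the chain. Trifluoromethyl removes that chain altogether and has never been measured here, so the direction is only a cautious guess. A step of similar modest size is expected, back toward higher numbers in this assay. The estimated change is a 2.2-fold higher number from compound 3 to compound 4 (0.34 log units; beyond the scatter). Compound 4 is expected at 35000 nM, with an estimated range from 11000 nM to 100000 nM.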

Compound 4, half-maximal cytotoxic concentration: 35000 nM
For compound 4 middle estimate and measured number coincide at the digits printed, within the range that was stated.
By their numbers in this assay, from the lowest: compound 3; then compounds 4 and 2 (each within the scatter of the next). At a limit, above all of these: compound 1.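

Going by these compounds alone, replacing isopropyl with trifluoromethyl gives a 2.2-fold higher number from compound 3 to compound 4 (0.34 log units; beyond the scatter), the first evidence that the number in this assay can move back up through a change at this aromatic carbon, rather than only down as it did with the earlier step from ethyl to isopropyl. Trifluoromethyl and ethyl cannot be told apart here, with a 1.2-fold lower number from compound 2 to compound 4 (0.10 log units; within the scatter), so among these three groups at this place only isopropyl stands apart, and compound 3 has the lowest number of the three. Within the data shown here, nothing measured here accounts for why isopropyl differs from the other two groups, since the only supporting information concerns a limit of the assay and has no bearing on this change.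

Among these compounds, with only three groups compared at this place on this core, it remains open whether the lower number of compound 3 reflects branched carbon chains in general or isopropyl alone, a question that a tert-butyl group or a cyclopropyl ring could help settle. Going by these compounds, how an amine or a carboxylic acid at the same carbon would read in this assay also remains open.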